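A few compounds are considered here, and "the series" means these few. Any claim that something is new, unique, unknown or untested is made for them only; others in the source may bear on it.

Three compounds built on one shared core have been examined in an ADME assay on cells (Mus musculus, strain Balb/c) for cytotoxicity, read by MTT assay, with a stated time of 48 h; on this read-out lower numbers stand for higher toxicity in this test and higher numbers for lower toxicity in this test. Compound 1 `COc1ccc(C(=O)/C=C/c2ccc(Br)cc2)cc1` gives 93700 nM in this assay, compound 2 `COc1ccc(C(/C=C/c2ccc(Br)cc2)=N/O)cc1` gives 737000 nM, and compound 3 `COc1ccc(C(/C=C/c2ccc(Cl)cc2Cl)=N/O)cc1` gives 25000 nM. Compound 2 thus holds the highest of the three numbers; compound 1 lies nearest to it and compound 3 furthest, with both gaps beyond the usual scatter. Compound 4 `COc1ccc(C(/C=C/c2ccccc2)=N/O)cc1` has not yet been measured. It differs from compound 2 by hydrogen in place of bromo on an aromatic carbon. Among the measured compounds shown here, no pair measured so far differs in only one place, so this step has no direct precedent among the known numbers. The step of a 1.2-fold higher number from compound 2 to compound 4 (0.09 log units; within the scatter) is expected to be small, within the scatter or a modest rise. Compound 4 is estimated at 900000 nM, between 300000 nM and 3000000 nM.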

Compound 4, half-maximal cytotoxic concentration: 28600 nM
Estimate against measurement, compound 4: 31-fold (1.50 log units) above, outside the stated range (below it).
By their numbers in this assay, from the lowest: compounds 3 and 4 (each within the scatter of the next); then compound 1; then compound 2.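

In this assay, among the compounds shown here, hydrogen in place of bromo on an aromatic carbon, para to a large group, gives a 26-fold lower number from compound 2 to compound 4 (1.41 log units; beyond the scatter), the first change in a single place seen here. This position is therefore far from silent in this test, with the bromo compound 2 showing the lower toxicity. No measured evidence bears on why the number moves so far. The compounds shown leave open whether a methoxy, an amine or a carboxylic acid at this position would sit nearer compound 2 or compound 4.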